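Trifluoromethyl added to the benzimidazole-free amide of compound 3

The compounds below may be only part of what the source reports. "The series", "measured", "known", "first", "only" and "open" are said of these compounds alone.

Compound 3 `CCC(=O)Nc1ccc(-c2nc3ccccc3[nH]2)cc1` is one of the simple anilides of the series. In an ADME assay on Vero cells (Chlorocebus sabaeus) for cytotoxicity (on this read-out lower numbers stand for higher toxicity in this test and higher numbers for lower toxicity in this test), compound 3 gives only a limit, > 100000 nM, not a number. Compound 4 `CCC(=O)Nc1ccc(-c2nc3cc(C(F)(F)F)ccc3[nH]2)cc1` carries trifluoromethyl in place of hydrogen on an aromatic carbon. Going by the values given here, none of the measured steps covers this change: the single step, an at least 3.2-fold higher number from compound 1 to compound 2 (0.50 log units; beyond the scatter), alters the amine on the saturated chain carbon bound to the carbonyl carbon, and both of its compounds already bear the trifluoromethyl. Compound 1 `O=C(CN1CCCCC1)Nc1ccc(-c2nc3cc(C(F)(F)F)ccc3[nH]2)cc1` gives 31000 nM in this assay. Compound 2 `O=C(CN1CCCC1)Nc1ccc(-c2nc3cc(C(F)(F)F)ccc3[nH]2)cc1` reaches only a limit, > 100000 nM, in this assay. So a trifluoromethyl is compatible with either outcome, and the limit of > 100000 nM in this assay, at which 2 of the 3 values shown sit, shows where most values sit. No step beyond the scatter is expected, an at least 1.2-fold lower number from compound 3 to compound 4 (0.09 log units; that floor lies within the scatter); compound 4 is estimated at 80000 nM (30000 nM to 200000 nM), most probably again a limit.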

Compound 4, half-maximal cytotoxic concentration: > 100000 nM
Compound 4: a limit, no number; the forecaster's own chance of this, stated with the estimate: 60%; middle value at least 1.2-fold (0.09 log units) from the limit.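

In this assay compound 4 gives a limit, > 100000 nM, not a number, so trifluoromethyl in place of hydrogen on this aromatic carbon gives no readable change in the simple anilide; the steps from compound 2 and from compound 3 to compound 4 cannot be read. With the trifluoromethyl kept, methyl in place of piperidin-1-yl gives an at least 3.2-fold higher number from compound 1 to compound 4 (0.50 log units; beyond the scatter). Compound 1 alone gives a number, and the others share one value: the limit of > 100000 nM in this assay, at which 3 of the 4 values shown sit.

Going by these compounds, whether trifluoromethyl at this position shifts the cytotoxic concentration at all stays open. Also open, on these data alone, is what a nitrile at this position, or a morpholine on the chain carbon, would give.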